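Series notes: chloro to methyl, from compound 3 to compound 4

This account rests on a few compounds, and the source may have more. Where it says the series, first, only, none or still open, it means among the compounds named here.

Measured in a functional assay on MOLT-4 cells (Homo sapiens), with a stated time of 72 h; on this read-out higher numbers stand for weaker inhibition and lower numbers for stronger inhibition:
- compound 1 `Cc1ccc(NC(=S)N/N=C2\C(=O)Nc3ccc(Br)cc32)cc1` gives 4900 nM
- compound 2 `O=C1/C(=N\NC(=S)Nc2ccc(Cl)cc2)c2cc(Br)ccc2N1Cc1ccc(F)cc1` gives 48000 nM
- compound 3 `Cc1ccc(CN2C(=O)/C(=N\NC(=S)Nc3ccc(Cl)cc3)c3cc(Br)ccc32)cc1` gives 74000 nM

Compound 3 gives the highest number of the three. Compound 2 stands within the scatter of it, so no order between these two is claimed; compound 1 gives a markedly lower number, beyond the scatter. Compound 4 `Cc1ccc(CN2C(=O)/C(=N\NC(=S)Nc3ccc(C)cc3)c3cc(Br)ccc32)cc1` differs from compound 3 by methyl in place of chloro on an aromatic carbon. Among the compounds with values here, no measured step matches this change. Within the data shown here, the only measured step, a 1.5-fold higher number from compound 2 to compound 3 (0.19 log units; within the scatter), concerns a different ring and lies within the scatter. Compound 1 carries the same methyl group but differs from compound 4 in more than one place, so its value gives no direct guide. The expected step is therefore small, a 1.2-fold lower number from compound 3 to compound 4 (0.09 log units; within the scatter), with no clear direction. Compound 4 is estimated at 60000 nM, with a range of 25000 nM to 150000 nM.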

Compound 4, half-maximal inhibitory concentration: 393000 nM
Compound 4: the middle estimate sits 6.6-fold (0.82 log units) below what was measured; measured number above the stated range.
By their numbers in this assay, from the lowest: compound 1; then compounds 2 and 3 (each within the scatter of the next); then compound 4.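

In this assay, within the data shown here, methyl in place of chloro on the aromatic carbon gives a 5.3-fold higher number from compound 3 to compound 4 (0.73 log units; beyond the scatter), so this position responds to a change of one heavy atom, which the only earlier step, on the other ring, did not show. The 4-methylbenzyl group on the ring nitrogen gives a larger step, an 80-fold higher number from compound 1 to compound 4 (1.90 log units; beyond the scatter), placing compound 4 at the high end of the series. Nothing at hand accounts for either step.

From the compounds shown here alone, how an amine or a carboxylic acid in place of the chloro would read out stays open. Also open, going by these compounds, is whether the chloro to methyl step keeps its size on a core that retains the amide hydrogen.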